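A few compounds are considered here, and "the series" means these few. Any claim that something is new, unique, unknown or untested is made for them only; others in the source may bear on it.

The measured compounds, each with its value in a functional assay for agonist activity at G protein-coupled receptor 88 (Homo sapiens), read by HTRF and cAMP accumulation; a lower number here means that less compound is needed, a higher number that more compound is needed for the effect:

compound 1, `CC(C)C[C@H](N)CN(C(=O)[C@@H]1C[C@H]1c1ccccc1)c1ccc(-c2ccc(F)cc2)cc1`, gives 900 nM;
compound 2, `CCc1ccc(-c2ccc(N(C[C@@H](N)[C@@H](C)CC)C(=O)[C@@H]3C[C@H]3c3ccccc3)cc2)cc1`, gives 44 nM;
compound 3, `CC[C@H](C)[C@H](N)CN(C(=O)[C@@H]1C[C@H]1c1ccccc1)c1ccc(-c2ccc(OC(C)C)cc2)cc1`, gives 72 nM.

Among these three, compound 3 holds the second highest number. For the measured compounds named here, its nearest neighbour is compound 2, and the only single-point step among the measured compounds runs between them: a 1.6-fold higher number from compound 2 to compound 3 (0.21 log units; within the scatter). Going by the values given here, compound 1, which carries a fluorine at the same place, gives a number far above both, which suggests that a larger group there is tolerated or even favoured, although with only three compounds this is a weak hint.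

Compound 4, `CC[C@H](C)[C@H](N)CN(C(=O)[C@@H]1C[C@H]1c1ccccc1)c1ccc(-c2ccc(COC(C)(C)C)cc2)cc1`, has not yet been measured. It differs from compound 3 in one place: (tert-butoxy)methyl in place of isopropoxy on an aromatic carbon. Among the compounds with values here, the only step that bears on this is the one from compound 2 to compound 3, which stayed within the scatter when one small group was swapped for another at this position. The new group is larger than either, so some loss cannot be ruled out, but nothing in the data points to a big change. Compound 4 is therefore expected to give about 110 nM in this assay, between 35 nM and 350 nM, which means an expected step of a 1.5-fold higher number from compound 3 to compound 4 (0.18 log units; within the scatter).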

Compound 4, half-maximal effective concentration: 280 nM
Estimate against measurement, compound 4: 2.5-fold (0.41 log units) below, and the stated range covers the measured number.
By their numbers in this assay, from the lowest: compounds 2 and 3 (each within the scatter of the next); then compound 4; then compound 1.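

In this assay, the step from isopropoxy to (tert-butoxy)methyl is a 3.9-fold higher number from compound 3 to compound 4 (0.59 log units; beyond the scatter), so this position does respond to the group it carries, and more compound is needed for the same effect. The comparison with the ethyl compound agrees, with a 6.4-fold higher number from compound 2 to compound 4 (0.80 log units; beyond the scatter), whereas the earlier swap gave only a 1.6-fold higher number from compound 2 to compound 3 (0.21 log units; within the scatter); ethyl and isopropoxy could not be told apart, but (tert-butoxy)methyl can be told apart from both, and the earlier hint that a larger group is tolerated here does not extend to it. No evidence is available on why this change raises the number.

The change from compound 3 to compound 4 alters two things at once, adding heavy atoms and putting a carbon between the oxygen and the ring, and the compounds shown cannot separate these; tert-butoxy or isopropoxymethyl at the same place would be needed to do that. Going by these compounds, how this position responds to a group of another kind, such as an amine or a carboxylic acid, also remains open.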